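Amide series: aryl carbonyl to propyl carbonyl

The source may report more compounds than this note shows. Statements on the series, on what has been measured and on what is new or still open speak of the compounds shown alone.

Measured compounds in a functional assay on NCI-H23 cells (Homo sapiens) for cytotoxicity, read by sulforhodamine B assay, with a stated time of 72 h; a lower number here means a stronger inhibitor of growth, a higher number a weaker inhibitor of growth:
- compound 1, `O=C(Nc1ccccc1C(F)(F)F)c1ccc2ccccc2n1`; compound 1 gives > 90000 nM, a limit of the assay and not a number.
- compound 2, `O=C(Nc1cc(C(F)(F)F)cc(C(F)(F)F)c1)C1CCc2ccccc2N1C(=O)c1ccc(Cl)cc1`; compound 2 gives 889 nM.
- compound 3, `O=C(Nc1cc(C(F)(F)F)cc(C(F)(F)F)c1)C1CCc2ccccc2N1C(=O)c1cccc(Cl)c1`; compound 3 gives 420 nM.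

Compound 3 holds the lowest of the two numbers; its nearest neighbour is compound 2, and the step of a 2.1-fold lower number from compound 2 to compound 3 (0.33 log units; beyond the scatter) is modest. Compound 4, `CCCC(=O)N1c2ccccc2CCC1C(=O)Nc1cc(C(F)(F)F)cc(C(F)(F)F)c1`, differs from compound 3 by propyl in place of 3-chlorophenyl on a carbonyl carbon. Going by the values given here, no measured step exchanges an aromatic group for a chain on this carbonyl carbon; the only measured step, a 2.1-fold lower number from compound 2 to compound 3 (0.33 log units; beyond the scatter), swaps one chlorophenyl for another and stays close to the scatter. The change to propyl removes the whole ring, so a shift to a higher number in this assay, beyond the scatter, is expected: a 3.6-fold higher number from compound 3 to compound 4 (0.55 log units; beyond the scatter). Compound 4 is estimated at 1500 nM, with a range from 400 nM to 6000 nM.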

Compound 4, concentration for 50% growth inhibition: 15000 nM
Beside the measured number, compound 4's estimate is 10-fold (1.00 log units) below it; the measured number lies above the stated range.
By their numbers in this assay, from the lowest: compound 3; then compound 2; then compound 4. At a limit, above all of these: compound 1.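

On this carbonyl carbon, replacing a chlorophenyl ring with a chain now has a measured cost in this assay: a 36-fold higher number from compound 3 to compound 4 (1.55 log units; beyond the scatter), and a 17-fold higher number from compound 2 to compound 4 (1.23 log units; beyond the scatter). Both steps are large, while exchanging one chlorophenyl for the other gives only a 2.1-fold lower number from compound 2 to compound 3 (0.33 log units; beyond the scatter), so among these compounds, having a chlorophenyl ring at this position matters more than which chlorophenyl it is. Nothing measured here gives a cause for these steps.

It remains open whether the ring itself or the chlorine drives this difference, as unsubstituted phenyl is not among the compounds shown. From the compounds shown here alone, whether cyclohexyl or a longer chain on this carbonyl carbon recovers the lower numbers also remains open.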